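The compounds below may be only part of what the source reports. "The series", "measured", "known", "first", "only" and "open" are said of these compounds alone.

Working notes on the series in a functional assay on A549 cells (Homo sapiens) for cytotoxicity, read by MTT assay, with a stated time of 48 h (on this read-out lower numbers stand for stronger inhibition and higher numbers for weaker inhibition), as read so far. Compound 1 `COc1c(OCc2cnoc2C)cc(O)c2c(=O)cc(-c3ccccc3)oc12` gives > 100000 nM as a limit and not a number. Compound 2 `CCN(CC)CCCOc1c(O)cc(O)c2c(=O)cc(-c3ccccc3)oc12` gives > 100000 nM as a limit too, so it has no numeric position in the series. Taken together, the data amount to the limit of > 100000 nM in this assay, at which 2 of the 2 values shown sit, and offer no measured step to size anything by.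

Compound 3 `CN(C)CCCCOc1c(O)cc(O)c2c(=O)cc(-c3ccccc3)oc12` differs from compound 2 by (dimethylamino)methyl in place of diethylamino on a saturated chain carbon, three bonds along the chain from an oxygen on an aromatic ring in one place: (dimethylamino)methyl in place of diethylamino on a saturated chain carbon, three bonds along the chain from an oxygen on an aromatic ring. The same difference reads 3-(diethylamino)propyl to 4-(dimethylamino)butyl.

With compound 2 resting at > 100000 nM as a limit, no step beyond the usual scatter is expected in either direction, and a further limit is the likeliest report. The expected change, a number no higher from compound 2 to compound 3 (the limit leaves the size open) in the estimate, is therefore small. For compound 3 the estimated value is 100000 nM within an expected range from 40000 nM to 200000 nM if a number is reported at all.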

Compound 3, half-maximal inhibitory concentration: > 100000 nM
Compound 3: a limit, no number (the forecaster's own chance of this, stated with the estimate: 70%); the middle value sits exactly at the limit.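

No step can be read between compound 2 and compound 3, as each stands as a limit and not a number: the limit of > 100000 nM in this assay, at which 3 of the 3 values shown sit.

The compounds shown leave open whether any of these side chains on the shared core gives a numeric value in this assay, and how large the change from 3-(diethylamino)propyl to 4-(dimethylamino)butyl is.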